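Aryl substituent variation: compound 3 to compound 4

This account rests on a few compounds, and the source may have more. Where it says the series, first, only, none or still open, it means among the compounds named here.

Measured compounds:
compound 1, `COc1ccc(-c2csc(N)c2C(=O)OCc2ccccc2)cc1`: 86%
compound 2, `Nc1scc(-c2cccc(C(F)(F)F)c2)c1C(=O)OCc1ccccc1`: 29%
compound 3, `Nc1scc(-c2cccc(F)c2)c1C(=O)OCc1ccccc1`: 53%

In an assay on isolated protein for inhibition of protein kinase C zeta type (Homo sapiens), with stated times of 1 h and 2.5 min, tested at 30 uM (on this read-out lower numbers stand for less inhibition and higher numbers for more inhibition at the one concentration tested (going by the name of the read-out)), compound 3 stands second highest of the three numbers, below compound 1 and above compound 2. Both steps reaching compound 3 change the group on the aryl ring: a number 33 percentage points lower from compound 1 to compound 3 (beyond the scatter) and a number 24 percentage points higher from compound 2 to compound 3 (beyond the scatter). Compound 4, `N#Cc1cccc(-c2csc(N)c2C(=O)OCc2ccccc2)c1`, differs from compound 3 by cyano in place of fluoro on an aromatic carbon. Among the measured compounds shown here, no measured step involves a cyano group, so the two steps above bear on it only as a sign that this position responds strongly to substitution. A change in this assay beyond the scatter is therefore expected, with direction uncertain; a modest downward step is taken as the working estimate, a number 11 percentage points lower from compound 3 to compound 4 (beyond the scatter). Compound 4 is thus expected to give 42%, within 15% to 70%.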

Compound 4, a percentage reported as inhibition, at one concentration (the size of the read-out at that concentration, not a potency): 25%
Estimate against measurement, compound 4: 17 percentage points above; low and high end bracket the measured number.
By their numbers in this assay, from the lowest: compounds 4 and 2 (each within the scatter of the next); then compound 3; then compound 1.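

In this assay, replacing fluoro with cyano costs further inhibition: a number 28 percentage points lower from compound 3 to compound 4 (beyond the scatter). Cyano and trifluoromethyl cannot be told apart, a number 4 percentage points lower from compound 2 to compound 4 (within the scatter), so among these three compounds fluoro alone keeps inhibition above that pair. The 3-cyanophenyl group also stands well short of 4-methoxyphenyl, a number 61 percentage points lower from compound 1 to compound 4 (beyond the scatter).

No evidence at hand bears on why cyano and trifluoromethyl read alike. As far as these compounds go, how an amine or a carboxylic acid on this aromatic carbon would compare with fluoro and cyano remains open.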